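A small thiazole amide series and its methyl analogue

The source may hold more compounds than are shown below. What is called first, only, known or untested is meant among the compounds shown, and "the series" means these compounds.

Measured compounds in a functional assay on MCF7 cells (Homo sapiens) for cytotoxicity, read by trypan blue exclusion, with a stated time of 48 h; a lower number here means a stronger inhibitor, a higher number a weaker inhibitor:
Compound 1, `O=C(COc1ccccc1)Nc1nc(-c2ccc(Br)cc2)cs1`: 54000 nM
Compound 2, `Cc1ccccc1OCC(=O)Nc1nc(-c2ccc(Br)cc2)cs1`: 39700 nM
Compound 3, `O=C(COc1ccccc1)Nc1nc(-c2ccc(Cl)cc2)cs1`: 55900 nM

All three numbers sit close together. Compound 2 differs from compound 1 by methyl in place of hydrogen on an aromatic carbon, and the step of a 1.4-fold lower number from compound 1 to compound 2 (0.13 log units; within the scatter) stays within the scatter. Compound 3 differs from compound 1 by chloro in place of bromo on an aromatic carbon, and the step of a 1.0-fold higher number from compound 1 to compound 3 (0.02 log units; within the scatter) is likewise within the scatter, so the two cores cannot be told apart on this evidence.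

Compound 4, `Cc1ccccc1OCC(=O)Nc1nc(-c2ccc(Cl)cc2)cs1`, has not been measured in this assay. It differs from compound 3 by methyl in place of hydrogen on an aromatic carbon, the same change that separates compound 2 from compound 1, at the same kind of place. Since the two cores showed no separable difference and the earlier methyl step was small, the step of a 1.4-fold lower number from compound 3 to compound 4 (0.13 log units; within the scatter) is expected to be of similar size. Compound 4 is therefore estimated at 41000 nM, with a range from 24000 nM to 72000 nM.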

Compound 4, half-maximal inhibitory concentration: 62800 nM
The estimate for compound 4 lay 1.5-fold (0.19 log units) below the measured number; the range from low to high includes it.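

In this assay, the methyl change on the core of compound 3 gives a 1.1-fold higher number from compound 3 to compound 4 (0.05 log units; within the scatter), and chloro in place of bromo, with the methyl present, gives a 1.6-fold higher number from compound 2 to compound 4 (0.20 log units; within the scatter). Set beside its earlier counterpart, the methyl change shows no separable difference between the two cores, but with both steps inside the scatter, this does not show that a real effect carries from one core to the other: the same change on two cores in this assay, a 1.4-fold lower number (0.13 log units; within the scatter) from compound 1 to compound 2 and a 1.1-fold higher number (0.05 log units; within the scatter) from compound 3 to compound 4, 1.5-fold (0.18 log units) apart, within the scatter of two such steps The same reading and the same limit apply to chloro in place of bromo: the same change on two cores in this assay, a 1.0-fold higher number (0.02 log units; within the scatter) from compound 1 to compound 3 and a 1.6-fold higher number (0.20 log units; within the scatter) from compound 2 to compound 4, 1.5-fold (0.18 log units) apart, within the scatter of two such steps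

Every step among these compounds lies within the scatter, so the compounds shown leave open whether any change in this series can move the number beyond it. They also leave open whether an amine or a carboxylic acid on the phenoxy ring, or a longer chain in place of the methyl, would give a step that could be told apart and carried from one core to the other.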